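This account rests on a few compounds, and the source may have more. Where it says the series, first, only, none or still open, it means among the compounds named here.

Three measured compounds set the scene. In a functional assay on the whole organism (B cells) with Mus musculus as the target (a higher number here means a larger maximal response, a lower number a smaller maximal response), compound 1 `C=CCn1/c(=N\C#N)n([C@H]2OC(CO)[C@@H](O)[C@H]2O)c2cc(N)nc(O)c21` gives 85%, compound 2 `COc1ccc(Cn2c(=O)n(C3OC(CO)[C@@H](O)[C@H]3O)c3nc(N)nc(O)c32)cc1` gives 44%, and compound 3 `C=CCn1c(=S)n(COCCO)c2nc(N)nc(O)c21` gives 9%. Compound 2 stands second highest of the three numbers: the nearest value, that of compound 3, lies lower beyond the scatter, and the furthest, that of compound 1, lies higher beyond the scatter. Compound 4 `CCCCn1c(=O)n(C2OC(CO)[C@@H](O)[C@H]2O)c2nc(N)nc(O)c21` has not yet been measured in this assay. It differs from compound 2 in one place: propyl in place of 4-methoxyphenyl on a saturated chain carbon bound to an aromatic nitrogen. Among the compounds with values here, no step between two measured compounds isolates this change, so the data give no direct guide to its size or direction. The step of a number 1 percentage points higher from compound 2 to compound 4 (within the scatter) is therefore expected to be small and could run either way, not clearly beyond the scatter. Compound 4 is expected to give about 45%, within a range from 25% to 65%.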

Compound 4, largest response reached (reported as maximal response), in percent of the reference or control that the assay uses: 86%
For compound 4 the middle estimate is 41 percentage points below the measured one; the measured number lies above the stated range.
By their numbers in this assay, from the lowest: compound 3; then compound 2; then compounds 1 and 4 (each within the scatter of the next).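

Within the data shown here, exchanging 4-methoxyphenyl for propyl on a saturated chain carbon bound to an aromatic nitrogen gives the first single-place step in this set, and in this assay it is a number 42 percentage points higher from compound 2 to compound 4 (beyond the scatter). The group at this place therefore strongly affects the maximal response, and the open chain of the butyl group gives the larger response here. Nothing measured here explains the step. The compounds shown leave open whether a plain benzyl group would behave like 4-methoxybenzyl or like butyl. They also leave open how a longer chain, such as hexyl, would respond at this place.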